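Working notes: substituent change beside the shared core

The source may hold more compounds than are shown below. What is called first, only, known or untested is meant among the compounds shown, and "the series" means these compounds.

Measured in a toxicity assay on HeLa cells (Homo sapiens) for cytotoxicity; a lower number here means that less compound is tolerated, a higher number that more compound is tolerated:
- Compound 1 `COc1nc(C2CCOCC2)ccc1[C@@H](c1ccccc1)[C@@](O)(CCN(C)C)c1cccc2ccccc12` gives 22.5 ug/mL.
- Compound 2 `COc1nc(-c2cccc(F)c2)ccc1[C@@H](c1ccccc1)[C@@](O)(CCN(C)C)c1cccc2ccccc12` gives 62.8 ug/mL.
- Compound 3 `COc1nc(-c2ccc(C(F)(F)F)cc2)ccc1[C@@H](c1ccccc1)[C@@](O)(CCN(C)C)c1cccc2ccccc12` gives only a limit, > 64 ug/mL.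

Compound 3 stands at the limit of > 64 ug/mL in this assay, at which 1 of the 3 values shown sits, so no number is known for it. Compound 4 `COc1nc(C(C)(C)C)ccc1[C@@H](c1ccccc1)[C@@](O)(CCN(C)C)c1cccc2ccccc12` differs by tert-butyl in place of 4-(trifluoromethyl)phenyl on an aromatic carbon. Among the measured compounds shown here, no measured step covers this change directly. The steps of a 2.8-fold higher number from compound 1 to compound 2 (0.45 log units; beyond the scatter) and an at least 2.8-fold higher number from compound 1 to compound 3 (0.45 log units; beyond the scatter) show that going from oxan-4-yl to an aromatic six-membered ring raised the number, while an at least 1.0-fold higher number from compound 2 to compound 3 (0.00 log units; that floor lies within the scatter) lies within the scatter. tert-Butyl, with no ring, is closer to the oxan-4-yl of compound 1 in that respect than to either aromatic group, so compound 4 is expected to fall between compound 1 and compound 3, estimated at 35 ug/mL (range 15 ug/mL to 64 ug/mL), a step of an at least 1.8-fold lower number from compound 3 to compound 4 (0.26 log units; that floor lies within the scatter).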

Compound 4, half-maximal cytotoxic concentration: > 64 ug/mL
Compound 4 gave a limit, no number; the forecaster's own chance of this, stated with the estimate: 30%; at least 1.8-fold (0.26 log units) between middle value and limit.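

In this assay the step of an at least 2.8-fold higher number from compound 1 to compound 4 (0.45 log units; beyond the scatter) comes with tert-butyl, which has no ring, so a rise over oxan-4-yl at this position does not require an aromatic ring. Against 3-fluorophenyl the reading is an at least 1.0-fold higher number from compound 2 to compound 4 (0.00 log units; that floor lies within the scatter) and gives no order between the two groups. The value of compound 4 is a limit, and the change from compound 3 cannot be read because both compounds sit at that limit: the limit of > 64 ug/mL in this assay, at which 2 of the 4 values shown sit.

On these data alone, whether the lower number of compound 1 goes with the ring oxygen of oxan-4-yl stays open. A cyclohexyl group or an amine in this place would test that in this assay and may give a number rather than a limit.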